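A Fluoro for Ethyl Swap on a Weak Series

The compounds below may be only part of what the source reports. "The series", "measured", "known", "first", "only" and "open" are said of these compounds alone.

Compound 1 `CCc1ccc2oc(CSc3nnc(CNc4ccccc4)n3CC)nc2c1`: > 1000 nM
Compound 2 `CCn1c(CNc2ccccc2)nnc1SCC(=O)Nc1ccc(C(=O)NC)cc1`: > 1000 nM

Both values come from an assay on isolated protein for inhibition of long-chain fatty acid transport protein 1 (Homo sapiens); a lower number here means a stronger inhibitor, a higher number a weaker inhibitor. For compound 1 the value > 1000 nM is a limit of the assay, not a measured number. The same is true of compound 2, whose value > 1000 nM is likewise a limit. Compound 1 therefore stands at the limit of > 1000 nM in this assay, at which 2 of the 2 values shown sit, and the two values do not say which of the two compounds is the stronger inhibitor.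

Compound 3 `CCn1c(CNc2ccccc2)nnc1SCc1nc2cc(F)ccc2o1` has not yet been measured. It differs from compound 1 in a single place: fluoro in place of ethyl on an aromatic carbon. Among the measured compounds shown here, no measured pair here changes only that group, so nothing shows how large a step such a swap brings. With both known values resting at the limit, the step expected in this assay is small: a step that the limit leaves unreadable from compound 1 to compound 3. Compound 3 is expected to give about 3000 nM, within 800 nM to 15000 nM, and quite possibly only another limit.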

Compound 3, half-maximal inhibitory concentration: > 1000 nM
Compound 3: no number, only a limit; the forecaster's own chance of this, stated with the estimate: 75%; the middle value does not contradict the limit.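

Compound 3 gives > 1000 nM, which is a limit and not a number. No step from compound 1 to compound 3 can be read: the limit of > 1000 nM in this assay, at which 3 of the 3 values shown sit.

As far as these compounds go, whether ethyl or fluoro on that aromatic carbon gives the stronger inhibitor stays open, as does the true strength of all three compounds.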